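An aryl amide swap on a shared enone core

The source may report more compounds than this note shows. Statements on the series, on what has been measured and on what is new or still open speak of the compounds shown alone.

In a functional assay on CLL cells (Homo sapiens) for cytotoxicity, read by MTT assay, with a stated time of 48 h (on this read-out higher numbers stand for an effect only at larger amounts of compound and lower numbers for an effect already at smaller amounts), compound 1 `C=C(CC)C(=O)c1ccc(OCC(=O)Nc2nc3ccccc3s2)c(Cl)c1Cl` gives 1500 nM, the lower of the two numbers obtained in this series. Compound 2 `C=C(CC)C(=O)c1ccc(OCC(=O)Nc2ccc3c(c2)C(=O)NC3=O)c(Cl)c1Cl` gives 2500 nM, a gap that stays within the scatter, so the two cannot be ranked. Compound 3 `C=C(CC)C(=O)c1ccc(OCC(=O)Nc2nc(/C(=N\OC)C(=O)O)cs2)c(Cl)c1Cl` gives > 25000 nM, which is a limit and not a number, namely (the limit of > 25000 nM in this assay, at which 1 of the 3 values shown sits).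

Compound 4 `C=C(CC)C(=O)c1ccc(OCC(=O)Nc2ccc(C(C)=O)cc2)c(Cl)c1Cl` differs from compound 1 by 4-acetylphenyl in place of 1,3-benzothiazol-2-yl on an amide-type nitrogen. For the measured compounds named here, no measured pair follows this change, so the expectation rests only on the spread seen across compounds 1 and 2. The expected step is a 2.0-fold higher number from compound 1 to compound 4 (0.30 log units; within the scatter), a slight weakening that may not exceed the scatter. Compound 4 is therefore estimated at 3000 nM, with a likely range from 1200 nM to 10000 nM.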

Compound 4, half-maximal effective concentration: 3900 nM
Compound 4: the middle estimate sits 1.3-fold (0.11 log units) below what was measured; measured number inside the range.
By their numbers in this assay, from the lowest: compounds 1, 2 and 4 (each within the scatter of the next, the first and the last beyond it). At a limit, above all of these: compound 3.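

For the compounds shown here, this pair gives the first step at this amide-type nitrogen in this assay: a 2.6-fold higher number from compound 1 to compound 4 (0.41 log units; beyond the scatter). It shows that exchanging 1,3-benzothiazol-2-yl for 4-acetylphenyl on the shared core can move the number beyond the scatter, though only modestly. No measurement shown here accounts for this step.

From the compounds shown here alone, it remains open whether a plain phenyl group would stay with compound 1 or with compound 4. Also open, going by these compounds, is how an amine or a carboxylic acid in place of the acetyl group would read.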